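A few compounds are considered here, and "the series" means these few. Any claim that something is new, unique, unknown or untested is made for them only; others in the source may bear on it.

Of the compounds shown here, three sharing one core have been tested in an ADME assay on HEK293 cells (Homo sapiens) for cytotoxicity, read by MTT assay, with a stated time of 48 h; a higher number here means a weaker inhibitor, a lower number a stronger inhibitor. There compound 1 `C=C1CCC[C@]2(C)CCC(C=O)=CC[C@@]12C` gives 734000 nM, compound 2 `C=C1CCC[C@]2(C)CCC(c3cn(-c4ccc(OC)cc4)nn3)=CC[C@@]12C` gives 410000 nM, and compound 3 `C=C1CCC[C@]2(C)CCC(c3cn(CC(=O)Nc4ccc(C)cc4)nn3)=CC[C@@]12C` gives 622000 nM. Compound 3 thus lies within the usual scatter of both others. Compound 4 `C=C1CCC[C@]2(C)CCC(c3cn(CC(=O)Nc4ccccc4)nn3)=CC[C@@]12C` changes compound 3 in one place: hydrogen in place of methyl on an aromatic carbon, with hydrogen in place of methyl on an aromatic carbon, para to a large group. Within the data shown here, no measured pair shows this change, so the expectation rests on compound 3 at 622000 nM, and no step beyond the scatter is expected in this assay. The estimated step runs a 1.1-fold lower number from compound 3 to compound 4 (0.03 log units; within the scatter). For compound 4 the estimated value is 580000 nM, with an expected range from 330000 nM to 1000000 nM.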

Compound 4, half-maximal inhibitory concentration: 491000 nM
The estimate for compound 4 lay 1.2-fold (0.07 log units) above the measured number; measured number inside the range.
By their numbers in this assay, from the lowest: compounds 2, 4, 3 and 1 (each within the scatter of the next).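

In this assay, hydrogen in place of methyl on the aromatic carbon para to a large group gives a 1.3-fold lower number from compound 3 to compound 4 (0.10 log units; within the scatter). Among these compounds, this is the first measured pair for this position, and it shows that going from 4-methylphenyl to phenyl leaves compound 3 and compound 4 indistinguishable in this assay. No measurement at hand offers an explanation for this result. On these data alone, whether a carboxylic acid or an amine at this position would give a step beyond the scatter remains open, as does whether a chlorine atom there would.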